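Lengthening an Alkoxy Chain on Compound 2

This account rests on a few compounds, and the source may have more. Where it says the series, first, only, none or still open, it means among the compounds named here.

This account concerns two measured compounds and one that awaits measurement. Compound 1 `COc1cccc(/C=C2\CCC/C(=C\c3ccccc3[N+](=O)[O-])C2=O)c1` and compound 2 `COc1cc(/C=C2\CCC/C(=C\c3ccccc3[N+](=O)[O-])C2=O)cc(Br)c1OC` were tested in a functional assay on SK-N-MC cells (Homo sapiens) for cytotoxicity, read by MTT assay; on this read-out higher numbers stand for weaker inhibition and lower numbers for stronger inhibition. Compound 1 gives 4.49 ug/mL in this assay, and compound 2 gives 6.24 ug/mL. Compound 2 thus stands alongside compound 1: the gap between the two values lies within the usual scatter of repeated measurements, so the two compounds cannot be told apart on these numbers.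

Compound 3 `CCCOc1c(Br)cc(/C=C2\CCC/C(=C\c3ccccc3[N+](=O)[O-])C2=O)cc1OC` has not yet been measured. It differs from compound 2 in one place: ethyl in place of hydrogen on a saturated chain carbon bound to an oxygen on an aromatic ring. Cut one bond further out, the same difference reads methyl to propoxy's propyl, methoxy to propoxy. Among the measured compounds shown here, no measured pair in this set shows what such a change does, so nothing here can anchor a direction. The step of a 1.1-fold lower number from compound 2 to compound 3 (0.05 log units; within the scatter) is therefore estimated to stay within the scatter, with no clear direction. Compound 3 is expected to give 5.5 ug/mL in this assay, with a range from 2.5 ug/mL to 12 ug/mL.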

Compound 3, half-maximal inhibitory concentration: 3.5 ug/mL
For compound 3 the middle estimate is 1.6-fold (0.20 log units) above the measured one; measured number inside the range.
By their numbers in this assay, from the lowest: compounds 3, 1 and 2 (each within the scatter of the next).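

In this assay, among the compounds shown here, the change from methoxy to propoxy gives a 1.8-fold lower number from compound 2 to compound 3 (0.25 log units; within the scatter) and so provides the first measured reading at this place, on a saturated chain carbon bound to an oxygen on an aromatic ring. It shows that ethyl can enter in place of hydrogen there, adding two carbons to the chain, without a shift that can be told apart from the scatter of repeated measurements; compound 2 and compound 3 therefore cannot be separated on these numbers, and the step gives no firm direction. Nothing among the data shown explains the small difference or says whether it has any real meaning.

As far as these compounds go, it remains open whether this tolerance extends to a longer chain such as hexyl, to a branched isopropoxy group, or to a chain ending in an amine or a carboxylic acid, any of which might move the number beyond the scatter. A single step on a single compound also leaves open whether the change from methoxy to propoxy would read the same way on another compound in this assay.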